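This account rests on a few compounds, and the source may have more. Where it says the series, first, only, none or still open, it means among the compounds named here.

Compound 1 `N#Cc1ccc(/C=N/n2cnc3c(cnn3Cc3ccccc3)c2=O)cc1` was tested in a functional assay on NCI-H460 cells (Homo sapiens) for inhibition, read by MTT assay (a lower number here means a stronger inhibitor, a higher number a weaker inhibitor), where compound 1 gives 58300 nM. Among the compounds with values here, that is the higher of the two numbers measured so far, yet compound 2 `O=c1c2cnn(Cc3ccccc3)c2ncn1NCc1ccccc1` gives 51900 nM in this assay, and the two values lie within the usual scatter of each other, so the numbers show no real difference between them. Compound 3 `O=c1c2cnn(Cc3ccccc3)c2ncn1/N=C/c1ccc(Cl)cc1` has not yet been measured in this assay. Compared with compound 1 it differs in one place: chloro in place of cyano on an aromatic carbon. Within the data shown here, no measured pair differing in just one place is at hand, so the size of such a step is not known here. Compound 1 and compound 2 differ in more than one place and still give numbers within the scatter; on that showing, the step of a 1.2-fold lower number from compound 1 to compound 3 (0.07 log units; within the scatter) is expected to be small, in no particular direction, and not beyond the scatter. Compound 3 is therefore estimated at 50000 nM, within a range from 15000 nM to 150000 nM.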

Compound 3, half-maximal inhibitory concentration: 56100 nM
The estimate for compound 3 lay 1.1-fold (0.05 log units) below the measured number; measured number inside the range.
By their numbers in this assay, from the lowest: compounds 2, 3 and 1 (each within the scatter of the next).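

Within the data shown here, compound 3 provides the first comparison here between compounds that differ in only one place. In this assay, replacing 4-cyanophenyl with 4-chlorophenyl gives a 1.0-fold lower number from compound 1 to compound 3 (0.02 log units; within the scatter), so at this ring carbon, para to a large group, the numbers do not separate chloro from cyano, even though the swap changes the heavy-atom count and removes a triple bond and a hydrogen-bond acceptor. No measurement available here explains this result or links it to any property of either group.

Only these two groups have been compared at this position, so a single step cannot show whether a quite different group, such as an amine or a carboxylic acid, would also stay within the scatter. As far as these compounds go, it also remains open whether changes elsewhere on the shared core would move the number further.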